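Cyclopentyl in place of cyclopropyl: compound 3 to compound 4

A few compounds are considered here, and "the series" means these few. Any claim that something is new, unique, unknown or untested is made for them only; others in the source may bear on it.

Measured in a physicochemical assay for solubility, in phosphate buffer, with a stated time of 18 h (a higher number here means a more soluble compound, a lower number a less soluble compound), so far
compound 1 `CC(C)(C)c1nc(-c2ccc[nH]2)c2cc(C(N)=O)c(N)nc2n1` gives 130000 nM
compound 2 `CC(C)(C)c1ccc2c(N)c(C#N)c(N)nc2n1` gives 14200 nM
compound 3 `N#Cc1c(N)nc2nc(C3CC3)ncc2c1N` gives 23000 nM

Compound 3 sits within the scatter of compound 2 and lies lower than compound 1, a gap beyond the scatter. Next comes compound 4 `N#Cc1c(N)nc2nc(C3CCCC3)ncc2c1N` with cyclopentyl in place of cyclopropyl on an aromatic carbon between two ring nitrogen atoms. Going by the values given here, no measured pair shows a change in one place only, so the data offer no direct guide. In this assay a moderate drop is expected, probably just beyond the scatter. The estimate means a 2.6-fold lower number from compound 3 to compound 4 (0.41 log units; beyond the scatter) as the expected step. Compound 4 is estimated at 9000 nM with 2500 nM to 25000 nM as the expected range.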

Compound 4, solubility: 89000 nM
The estimate for compound 4 lay 9.9-fold (1.00 log units) below the measured number, and the stated range ends below it.
By their numbers in this assay, from the lowest: compounds 2 and 3 (each within the scatter of the next); then compounds 4 and 1 (each within the scatter of the next).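

In this assay, going by these compounds alone, the first change in one place gives a 3.9-fold higher number from compound 3 to compound 4 (0.59 log units; beyond the scatter) with cyclopentyl in place of cyclopropyl on the aromatic carbon between two ring nitrogen atoms. The larger carbon ring at this position therefore goes with a higher number, not a lower one, on the shared core. No measurement on hand accounts for this step.

As far as these compounds go, this single pair sets no trend with ring size, so the outcome with cyclobutyl or cyclohexyl stays open. From the compounds shown here alone, an amine or a carboxylic acid at this position also remains untested here.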